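Swapping ethyl for chloro on the cinnamide aryl ring

A few compounds are considered here, and "the series" means these few. Any claim that something is new, unique, unknown or untested is made for them only; others in the source may bear on it.

Compound 1 `CCCc1cc(N)c2cc(NC(=O)/C=C/c3ccc(CC)cc3)ccc2n1` is tested in a functional assay on HEK293 cells for activation of melanin-concentrating hormone receptor 1 (Homo sapiens), read by inositol phosphate accumulation (a lower number here means that less compound is needed, a higher number that more compound is needed for the effect), and gives 160 nM. Among the three measured compounds this is the lowest number: compound 3 `CCCc1cc(OC)c2cc(NC(=O)/C=C/c3ccc(C(F)(F)F)cc3)ccc2n1` gives 360 nM, and compound 2 `CCCc1cc(N2CCC2)c2cc(NC(=O)/C=C/c3ccc(C(F)(F)F)cc3)ccc2n1` gives 2500 nM. Compounds 2 and 3 share a trifluoromethyl group on the outer ring and differ from compound 1 in more than one place, so their values cannot be attributed to any single change. Within the data shown here, the one single-point step among them, a 6.9-fold lower number from compound 2 to compound 3 (0.84 log units; beyond the scatter), concerns the group on the core and not the outer ring.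

Compound 4 `CCCc1cc(N)c2cc(NC(=O)/C=C/c3ccc(Cl)cc3)ccc2n1` differs from compound 1 by chloro in place of ethyl on an aromatic carbon. Among the measured compounds shown here, no measured step concerns this position, so the expectation rests only on the fact that two small, uncharged groups with no donors or acceptors are exchanged there. Nothing in the measured values suggests a change beyond the usual scatter, so the expected step of a 1.3-fold higher number from compound 1 to compound 4 (0.10 log units; within the scatter) is small. Compound 4 is therefore estimated at 200 nM in this assay. The value of compound 4 is expected to lie no lower than 80 nM and is expected to lie no higher than 500 nM.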

Compound 4, half-maximal effective concentration: 96 nM
Compound 4: the middle estimate sits 2.1-fold (0.32 log units) above what was measured; measured number inside the range.
By their numbers in this assay, from the lowest: compounds 4 and 1 (each within the scatter of the next); then compound 3; then compound 2.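

In this assay, among these compounds, chloro in place of ethyl on the outer ring gives a 1.7-fold lower number from compound 1 to compound 4 (0.22 log units; within the scatter), the only measured step at this position with the rest of the molecule held fixed. It shows that, on the core of compound 1, the outer ring can carry either 4-ethylphenyl or 4-chlorophenyl with no difference that can be told from the scatter of repeated measurements, something compounds 2 and 3 could not show, since they differ from compound 1 in more than one place. With so small a step, there is nothing here to explain, and no outside measurement bears on this exchange.

From the compounds shown here alone, what a longer chain such as butyl, an amine or a carboxylic acid would do at this position remains open, as does whether trifluoromethyl would read like ethyl and chloro on the core of compound 1. Going by these compounds, it is also open whether ethyl and chloro would still read alike when the amino group on the core is replaced by methoxy or azetidin-1-yl, the groups carried by compounds 3 and 2.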